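A few compounds are considered here, and "the series" means these few. Any claim that something is new, unique, unknown or untested is made for them only; others in the source may bear on it.

Three compounds of the series have been assessed in an assay on HEK293 cells for inhibition of N-acylethanolamine-hydrolyzing acid amidase (Rattus norvegicus), read by LC-MS, with a stated time of 30 min; on this read-out lower numbers stand for stronger inhibition and higher numbers for weaker inhibition. Compound 1 `O=C(CCc1ccc(-c2cccc(Cl)c2)cc1)N1CCCC1` gives 25400 nM and compound 2 `O=C(CCc1ccc(-c2ccc(Cl)cc2)cc1)N1CCCC1` gives 48600 nM; the step of a 1.9-fold higher number from compound 1 to compound 2 (0.28 log units; within the scatter) sits within the scatter. Compound 3 `O=C(CCc1ccc(-c2ccccn2)cc1)N1CCCC1` carries pyridin-2-yl on the aromatic carbon in place of the chlorophenyl groups. For compound 3 the reading of > 100000 nM is a limit of this assay, not a number. Compound 3 thus stands at the weak end of the three values shown, sitting at the limit of > 100000 nM in this assay, at which 1 of the 3 values shown sits. The steps of an at least 3.9-fold higher number from compound 1 to compound 3 (0.59 log units; beyond the scatter) and an at least 2.0-fold higher number from compound 2 to compound 3 (0.31 log units; beyond the scatter) are both beyond the scatter, and each ends at the limit.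

Compound 4 `O=C(CCc1ccc(-c2cccnc2)cc1)N1CCCC1` is the next compound. The change is pyridin-3-yl in place of pyridin-2-yl on an aromatic carbon. Among the measured compounds shown here, no measured step moves between two pyridyl isomers; the steps into compound 3 only show that exchanging a chlorophenyl for pyridin-2-yl pushed the number to the limit, and they give no direction for a shift within the pyridyl pair. With compound 3 at the limit, a return to a measurable number would need a lowering at least as large as the measured steps into compound 3, and the shown data give no basis to expect it. The expected step of a number no higher from compound 3 to compound 4 (the limit leaves the size open) is therefore none beyond the scatter, with the reading most likely again a limit. Compound 4 is estimated at 100000 nM, in the range 40000 nM to 300000 nM.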

Compound 4, half-maximal inhibitory concentration: > 100000 nM
Compound 4 gave a limit, no number; the forecaster's own chance of this, stated with the estimate: 60%; the middle value sits exactly at the limit.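

Among the compounds shown here, at this position, on an aromatic carbon para to a group of 9 heavy atoms, pyridin-2-yl is no longer the only pyridyl group to end at a limit: in this assay compound 4 gives > 100000 nM, which is a limit of the assay and not a number. The shift away from the chlorophenyl compounds also holds for pyridin-3-yl, with an at least 2.0-fold higher number from compound 2 to compound 4 (0.31 log units; beyond the scatter) and an at least 3.9-fold higher number from compound 1 to compound 4 (0.59 log units; beyond the scatter), so it is not confined to one pyridyl isomer. The step between the two pyridyl compounds cannot be read, and no order of the two follows from it, while the limit now holds both of them: the limit of > 100000 nM in this assay, at which 2 of the 4 values shown sit.

On these data alone, whether pyridin-4-yl or an unsubstituted phenyl at this position would give a measurable number remains open, and with it whether the ring nitrogen or the missing chlorine separates compound 3 and compound 4 from compound 1 and compound 2. Also open, as far as these compounds go, is whether a chloropyridinyl group would bring the reading back within the range of the assay, and how far compound 3 and compound 4 lie beyond their limits.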